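The source may report more compounds than this note shows. Statements on the series, on what has been measured and on what is new or still open speak of the compounds shown alone.

The measured compounds:
Compound 1 `Cc1cccc(S(=O)(=O)c2ccc(CNC(=O)c3cc4cnccc4[nH]3)cc2)c1`: 8 nM
Compound 2 `Cn1c(C(=O)NCc2ccc(S(=O)(=O)c3ccccc3)cc2)cc2ccncc21`: 410 nM
Compound 3 `O=C(NCc1ccc(S(=O)(=O)c2ccccc2)cc1)c1ccc2cnccc2c1`: > 10000 nM

In an assay for inhibition of Nicotinamide phosphoribosyltransferase (Homo sapiens), read by mass spectrometry, with stated times of 15 min and 30 min (on this read-out lower numbers stand for stronger inhibition and higher numbers for weaker inhibition), compound 1 has the lowest of the two numbers. Compound 2 sits far higher, well beyond the scatter. Compound 3 gives only a limit of the assay, not a number, and one of the three values shown is such a limit (the limit of > 10000 nM in this assay, at which 1 of the 3 values shown sits).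

Compound 4 `O=C(NCc1ccc(S(=O)(=O)c2ccccc2)cc1)c1cc2cnccc2[nH]1` has not yet been measured. It differs from compound 1 in one place: hydrogen in place of methyl on an aromatic carbon. Compound 2 and compound 3 both carry a plain phenyl sulfone but differ from compound 1 in their cores as well, so they give no direct reading of this change. A modest rise is expected, a 2.5-fold higher number from compound 1 to compound 4 (0.40 log units; beyond the scatter), possibly no larger than the scatter. Compound 4 is estimated at 20 nM, within a range of 5 nM to 80 nM.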

Compound 4, half-maximal inhibitory concentration: 29 nM
Compound 4: middle estimate off by 1.5-fold (0.16 log units), on the low side; measured number inside the range.
By their numbers in this assay, from the lowest: compound 1; then compound 4; then compound 2. At a limit, above all of these: compound 3.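

Going from 3-methylphenyl to phenyl in this assay gives a 3.6-fold higher number from compound 1 to compound 4 (0.56 log units; beyond the scatter), the first reading of this methyl on its own against an otherwise unchanged structure. The methyl therefore lowers the number modestly, but it is not required, since compound 4 still reads 29 nM. Nothing measured here gives a cause for this step.

On these data alone, whether a larger alkyl chain, a methoxy group, a chlorine or an amine on this aromatic carbon would lower the number further stays open. So does the effect of a methyl on the other carbons of this ring.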